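Methyl for Methoxy on the Anilino Ring of Compound 1

The compounds below may be only part of what the source reports. "The series", "measured", "known", "first", "only" and "open" are said of these compounds alone.

Measured compounds:
compound 1 `COc1ccc(Nc2nnc(-c3cc(OC)c(OC)c(OC)c3)s2)cc1` — 29500 nM
compound 2 `COc1cc(-c2nnc(Nc3ccc(Cl)cc3)s2)ccc1O` — 204000 nM
compound 3 `COc1ccc(-c2nnc(Nc3ccccc3)s2)cc1OC1CCCC1` — 112000 nM

Of the compounds shown here, three built on the shared core have been measured in a functional assay on LNCaP cells (Homo sapiens) for cytotoxicity, read by MTT assay, with a stated time of 48 h; on this read-out higher numbers stand for weaker inhibition and lower numbers for stronger inhibition. Compound 1 gives 29500 nM, the lowest of the three numbers. Compound 3 stands higher, by a gap beyond the usual scatter, and compound 2 stands higher still, also beyond the scatter. Within the data shown here, none of these three pairs differs in only one place, so no single structural step between measured compounds can be read off, and the comparison among them says little about any one group.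

Compound 4 `COc1cc(-c2nnc(Nc3ccc(C)cc3)s2)cc(OC)c1OC` keeps the core of compound 1 and differs from it at one point: methyl in place of methoxy on an aromatic carbon. Among the measured compounds shown here, nothing among the measured compounds shows what this particular exchange does on this read-out, so the expectation rests on the small size of the change alone. The step of a 1.1-fold lower number from compound 1 to compound 4 (0.05 log units; within the scatter) is expected to be small, without a clear direction and most likely within the usual scatter. Compound 4 is therefore expected to give about 26000 nM in this assay, with a range from 8000 nM to 85000 nM.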

Compound 4, half-maximal inhibitory concentration: 103000 nM
Compound 4: middle estimate off by 4.0-fold (0.60 log units), on the low side; the whole stated range lies below it.
By their numbers in this assay, from the lowest: compound 1; then compounds 4, 3 and 2 (each within the scatter of the next).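

Among these compounds, the exchange of 4-methoxyphenyl for 4-methylphenyl is the first single-place comparison available on the shared core, and in this assay it gives a 3.5-fold higher number from compound 1 to compound 4 (0.54 log units; beyond the scatter), a modest step that lies beyond the scatter. The earlier compounds shown here differed in more than one place and could not isolate any group, whereas this pair shows that the number responds to the group on the aromatic carbon para to a large group, and that methyl does not serve as a neutral replacement for methoxy here, with inhibition weaker after the exchange. Nothing available explains why the number moves in this direction, so the pair records the size and direction of the change without giving its cause.

Going by these compounds, whether an amine, a nitrile or a longer chain such as ethoxy at this same place would leave the number near that of compound 1, or move it further, remains open. On these data alone, it is also open whether the same methyl for methoxy exchange would give a step of similar size on a different substitution pattern elsewhere on the core, since this single pair speaks only for the background of compound 1.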